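Swapping a Dichlorophenoxy Ether for a Methoxyphenyl Thioether

This account rests on a few compounds, and the source may have more. Where it says the series, first, only, none or still open, it means among the compounds named here.

Compound 1 `Nc1cc(N)c2nc(-c3ccccc3)c(Oc3ccc(Cl)c(Cl)c3)nc2c1` is a diamine built on a fused two-ring core that carries a phenyl group and a 3,4-dichlorophenoxy group. In a functional assay on A549 cells (Homo sapiens) for inhibition, read by sulforhodamine B assay, with a stated time of 48 h (on this read-out higher numbers stand for lower toxicity in this test and lower numbers for higher toxicity in this test), compound 1 gives < 100000 nM, which is a limit of the assay rather than a number. Two related compounds share the same core with a different group in that position. In this assay compound 2 `CCOC(=O)[C@H](CCC(=O)O)NC(=O)c1ccc(CNc2nc3cc(N)cc(N)c3nc2-c2ccccc2)cc1` gives < 100000 nM, again a limit. In this assay compound 3 `COc1ccc(CNc2nc3cc(N)cc(N)c3nc2-c2ccccc2)cc1` gives < 100000 nM, also a limit. All three measured values therefore sit at one place, (the limit of < 100000 nM in this assay, at which 3 of the 3 values shown sit), so compound 1 cannot be ranked against the other two on these numbers.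

Compound 4 `COc1ccc(Sc2nc3cc(N)cc(N)c3nc2-c2ccccc2)cc1` has not yet been measured. It differs from compound 1 in a single place: (4-methoxyphenyl)sulfanyl in place of 3,4-dichlorophenoxy on an aromatic carbon. No step between measured compounds is available, and every shown value is a limit, so no shift beyond the scatter is expected in this assay in either direction. Compound 4 is expected to give about 30000 nM, within a range from 5000 nM to 100000 nM. The step that the limit leaves unreadable from compound 1 to compound 4 is estimated to be small.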

Compound 4, concentration lethal to 50% of the cells: < 100000 nM
Compound 4 was reported as a limit; the forecaster's own chance of this, stated with the estimate: 70%; the middle value is on the limit's open side.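

Compound 1 and compound 4 are both reported as limits of the assay, not as numbers, so no step between them can be read: the limit of < 100000 nM in this assay, at which 4 of the 4 values shown sit.

The compounds shown leave open whether (4-methoxyphenyl)sulfanyl in place of 3,4-dichlorophenoxy changes the result in this assay at all, and how compound 1 and compound 4 would rank on actual numbers.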